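A few compounds are considered here, and "the series" means these few. Any claim that something is new, unique, unknown or untested is made for them only; others in the source may bear on it.

Compound 1 `O=C(CN(c1ncnc2c1ncn2C1CCCCO1)C1CC1)N[C@@H](CCC(=O)OCc1ccccc1)C(=O)OCc1ccccc1` was tested in a functional assay on the whole organism (Tail, strain ICR) with Mus musculus as the target, in the tail flick test, with a stated time of 60 min, at a dose of 25 umol/kg by the oral route (a lower number here means a weaker effect, a higher number a stronger effect of the compound at the dose given), and gave 34.7%. Compound 2 `CC[C@H](C)[C@H](NC(=O)CN(c1nc(Cl)nc2[nH]cnc12)C1CC1)C(=O)O` gave 36% in this assay, and compound 3 `C[C@@H](O)[C@H](NC(=O)CN(c1nc(Cl)nc2[nH]cnc12)C1CC1)C(=O)OCc1ccccc1` gave 29.7%. Compound 1 stands second highest of these three numbers, but its gaps to compound 2 and to compound 3 both lie within the usual scatter, so the three compounds cannot be told apart on these readings.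

Compound 4 `CSCC[C@H](NC(=O)CN(c1ncnc2c1ncn2C1CCCCO1)C1CC1)C(=O)OCc1ccccc1` has not yet been measured. It differs from compound 1 in one place: methylsulfanyl in place of benzyloxycarbonyl on a saturated chain carbon, three bonds along the chain from an amide-type nitrogen and a carbonyl carbon. Going by the values given here, no measured pair shows what this change does. For compound 4 the expected step is a number 1.7 percentage points lower from compound 1 to compound 4 (within the scatter), that is, no change beyond the scatter in either direction. Compound 4 is therefore estimated at 33%, with a range from 20% to 47%.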

Compound 4, a percentage reported as activity, at one dose (the size of the read-out at that dose, not a potency): 41%
The estimate for compound 4 lay 8 percentage points below the measured number; low and high end bracket the measured number.
By their numbers in this assay, from the lowest: compounds 3, 1, 2 and 4 (each within the scatter of the next, the first and the last beyond it).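

In this assay, replacing benzyloxycarbonyl with methylsulfanyl on this saturated chain carbon gives a number 6.3 percentage points higher from compound 1 to compound 4 (within the scatter). Going by these compounds alone, this is the first direct test of this position: a group of 10 heavy atoms with an aromatic ring gives way to one of 2 heavy atoms with no ring, and the read-out does not move beyond the scatter. At this single dose, then, the aromatic ring of the benzyloxycarbonyl group is not needed to keep the effect.

As far as these compounds go, whether an amine or a longer chain at this place would also hold the effect remains open. Nothing available explains the outcome of this exchange.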